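The source may report more compounds than this note shows. Statements on the series, on what has been measured and on what is new or still open speak of the compounds shown alone.

Compound 1 `Cc1ccnc(/C(N)=N/NC(=S)N2CCSCC2)c1`: 41.1%
Compound 2 `Cc1cccc(/C(N)=N/NC(=S)N2CCCCC2)n1`: 27%
Compound 3 `N/C(=N\NC(=S)N1CCCCCC1)c1ccccn1`: 21.3%

All three were tested in a functional assay on HeLa cells (Homo sapiens) for cytotoxicity, read by MTT assay, with a stated time of 72 h, tested at 1 uM; on this read-out lower numbers stand for less inhibition of growth and higher numbers for more inhibition of growth at the one concentration tested. Compound 1 gives 41.1%, the highest number of the three. Compound 2 gives 27% and compound 3 gives 21.3%; each of these sits below compound 1 by a margin beyond the usual scatter, so compound 1 stands as the most active of this small set.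

Compound 4 `Cc1ccnc(/C(N)=N/NC(=S)N2CCOCC2)c1` has not yet been measured. It differs from compound 1 in a single place: morpholin-4-yl in place of thiomorpholin-4-yl on a thiocarbonyl carbon. The ring that enters has the same size and the same count of hetero atoms as the one that leaves, with an oxygen where the sulfur stood. Going by the values given here, no two of the measured compounds differ in just this way, so no measured step can serve as a guide.

The expected step in this assay is modest, probably not beyond the scatter, with a lean toward slightly less inhibition of growth: a number 7.1 percentage points lower from compound 1 to compound 4 (within the scatter) is the expected shift. Compound 4 is accordingly expected to give about 34%, with a likely range from 20% to 48%.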

Compound 4, percent growth inhibition at one concentration: 39.1%
Beside the measured number, compound 4's estimate is 5.1 percentage points below it; measured number inside the range.
By their numbers in this assay, from the lowest: compounds 3 and 2 (each within the scatter of the next); then compounds 4 and 1 (each within the scatter of the next).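

In this assay, going by these compounds alone, swapping morpholin-4-yl in for thiomorpholin-4-yl on a thiocarbonyl carbon gives a number 2 percentage points lower from compound 1 to compound 4 (within the scatter) and so provides the first direct comparison at this position. For this one pair, the ring sulfur is therefore not needed to keep the number at this level: an oxygen in its place, in a ring of the same size with the same count of hetero atoms, gives a result that cannot be told apart from that of compound 1. Nothing available explains why this exchange leaves the read-out within the scatter, and no supporting measurement bears on the question.

Compound 2 and compound 3 each differ from compound 1 in more than one place, so they cannot show how a ring without a second hetero atom, such as piperidin-1-yl, would behave on the core of compound 1. From the compounds shown here alone, it also remains open whether a piperazin-1-yl ring or an open-chain dimethylamino group on the same thiocarbonyl carbon would keep the number in this range or move it beyond the scatter.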